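The source may hold more compounds than are shown below. What is called first, only, known or untested is meant among the compounds shown, and "the series" means these compounds.

Compound 1 `COc1ccc(N2C[C@@H](C)N[C@@H](C)C2)cc1NS(=O)(=O)c1ccc(-c2ccccc2)cc1` gives 1
Compound 2 `COc1ccc(N2C[C@@H](C)N[C@@H](C)C2)cc1NS(=O)(=O)c1ccc(N2CCCC2=O)cc1` gives 0.8

In a functional assay for agonist activity at growth hormone secretagogue receptor type 1 (Homo sapiens), read by FLIPR (a higher number here means a larger maximal response, a lower number a smaller maximal response), compound 2 stands lowest of the two numbers, its nearest neighbour being compound 1, from which the step a number 0.20 lower from compound 1 to compound 2 (beyond the scatter) ran. Compound 3 `COc1ccc(N2C[C@@H](C)N[C@@H](C)C2)cc1NS(=O)(=O)c1ccc(Oc2ccccc2)cc1` differs from compound 2 by phenoxy in place of 2-oxopyrrolidin-1-yl on an aromatic carbon. Going by the values given here, the only measured step, a number 0.20 lower from compound 1 to compound 2 (beyond the scatter), concerns the same position and is modest; since phenoxy, like phenyl, brings a six-membered aromatic ring of carbon only, a step back up of similar size is expected. The estimate for compound 3 is therefore 0.9, within 0.75 to 1, a step of a number 0.10 higher from compound 2 to compound 3 (within the scatter).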

Compound 3, intrinsic activity: the largest response reached, as a fraction of the reference agonist's: 0.9
The estimate for compound 3 equals the measured number at the digits printed; the range from low to high includes it.
By their numbers in this assay, from the lowest: compounds 2, 3 and 1 (each within the scatter of the next, the first and the last beyond it).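

In this assay, phenoxy at this position cannot be told apart from either of the other two groups: a number 0.10 higher from compound 2 to compound 3 (within the scatter) and a number 0.10 lower from compound 1 to compound 3 (within the scatter), although phenyl and 2-oxopyrrolidin-1-yl differ beyond the scatter. Adding the oxygen of phenoxy to the phenyl group therefore leaves no readable change in the maximal response. No measured evidence explains this result. As far as these compounds go, it remains open how an amine, a carboxylic acid or a longer alkyl chain on this aromatic carbon would behave.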